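Methoxy removal at a flanking aryl ring: working notes

This account rests on a few compounds, and the source may have more. Where it says the series, first, only, none or still open, it means among the compounds named here.

Measured so far in a functional assay on A549 cells (Homo sapiens) for inhibition, read by sulforhodamine B assay, with a stated time of 48 h; a lower number here means a stronger inhibitor of growth, a higher number a weaker inhibitor of growth:
compound 1, `COc1cc(C=C(C(=O)/C=C/c2ccc(OC)c(OC)c2)C(=O)/C=C/c2ccc(OC)c(OC)c2)ccc1O`, gives 530 nM
compound 2, `COc1ccc(/C=C/C(=O)C(=Cc2ccc(O)cc2)C(=O)/C=C/c2ccc(OC)c(OC)c2)cc1OC`, gives 420 nM
compound 3, `COc1cc(/C=C/C(=O)C(=Cc2cccc(OC)c2OC)C(=O)/C=C/c2ccc(O)c(OC)c2)ccc1O`, gives 420 nM

Going by the values given here, the one single-point step measured so far, a 1.3-fold lower number from compound 1 to compound 2 (0.10 log units; within the scatter), belongs to hydrogen in place of methoxy on an aromatic carbon. Compound 3 stands level with compound 2 at the digits given and within the scatter of compound 1; how the core of compound 1 and the core of compound 3 differ is not broken down here.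

Compound 4, `COc1cccc(C=C(C(=O)/C=C/c2ccc(O)c(OC)c2)C(=O)/C=C/c2ccc(O)c(OC)c2)c1`, has not yet been measured. It differs from compound 3 by hydrogen in place of methoxy on an aromatic carbon. This is the same kind of change as from compound 1 to compound 2, not the same change: there the carbon was ortho to a hydroxy group and meta to a large group, here it is ortho to a large group and ortho to a methoxy group.

The expected step is no change at the digits printed from compound 3 to compound 4 (within the scatter), a small one, because a 1.3-fold lower number from compound 1 to compound 2 (0.10 log units; within the scatter) stayed within the scatter for the same kind of change. On that basis compound 4 is estimated at 420 nM in this assay, with an expected span from 200 nM to 900 nM.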

Compound 4, concentration for 50% growth inhibition: 640 nM
For compound 4 the middle estimate is 1.5-fold (0.18 log units) below the measured one; low and high end bracket the measured number.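

In this assay, hydrogen in place of methoxy, here 2,3-dimethoxyphenyl to 3-methoxyphenyl, gives a 1.5-fold higher number from compound 3 to compound 4 (0.18 log units; within the scatter). Set beside the earlier step, the two cores do not separate: the same change on two cores in this assay, a 1.3-fold lower number (0.10 log units; within the scatter) from compound 1 to compound 2 and a 1.5-fold higher number (0.18 log units; within the scatter) from compound 3 to compound 4, 1.9-fold (0.28 log units) apart, within the scatter of two such steps. Within these two pairs, the change can be carried from one core to the other with the number staying inside the scatter each time, even though it sits at a different place on the aromatic ring in each pair; this does not show that the two steps are equal, that their opposite directions are real, or that the same result would hold on any further core in the series.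

The compounds shown leave open whether a group of another kind at the place ortho to a large group and ortho to a methoxy group, such as an amine or a carboxylic acid, would move the number beyond the scatter. They also leave open whether removing a methoxy group from a 3-methoxyphenyl ring, or replacing the hydroxy groups on the flanking rings, would do so.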